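Phenyl to 4-Chlorophenyl: an Expected Small Step

The source may report more compounds than this note shows. Statements on the series, on what has been measured and on what is new or still open speak of the compounds shown alone.

Compound 1 `CCOC(=O)c1c(N2CCCC2)[nH]c2ccc(O)cc12`: "not determined" (no result reported)
Compound 2 `CCOC(=O)c1c(N2CCN(c3ccccc3)CC2)[nH]c2ccc(O)cc12`: 79%

Among the measured compounds shown here, in an assay on isolated protein for inhibition of Polyunsaturated fatty acid 5-lipoxygenase (Homo sapiens), tested at 10 uM (on this read-out lower numbers stand for less inhibition and higher numbers for more inhibition at the one concentration tested (going by the name of the read-out)), compound 2 gives 79%, the only number in this set, since compound 1 stands at "not determined" (no result reported). Compound 3 `CCOC(=O)c1c(N2CCN(c3ccc(Cl)cc3)CC2)[nH]c2ccc(O)cc12` differs from compound 2 by one change (chloro in place of hydrogen on an aromatic carbon). For the measured compounds named here, with no measured step between any two compounds, there is nothing to calibrate the size of this change, so the step from compound 2 to compound 3 is expected to stay within the scatter, a number 1 percentage points higher from compound 2 to compound 3 (within the scatter). Compound 3 is therefore estimated at 80% in this assay, within a range from 62% to 92%.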

Compound 3, a percentage reported as inhibition, at one concentration (the size of the read-out at that concentration, not a potency): 69%
For compound 3 the middle estimate is 11 percentage points above the measured one; measured number inside the range.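

Among the compounds shown here, with chloro in place of hydrogen on an aromatic carbon, para to a large group, the set gains its first measured step in this assay, which reads a number 10 percentage points lower from compound 2 to compound 3 (within the scatter) and gives a first size for a change at this place. The 4-chlorophenyl group thus keeps compound 3 within the scatter of compound 2, a finding that holds for this one pair only. Nothing available bears on why the number falls where it does.

On these data alone, whether a methoxy group, an amine or a carboxylic acid at the same place would also stay within the scatter remains open.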